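Methyl-to-ethyl change on the core of compound 2

A few compounds are considered here, and "the series" means these few. Any claim that something is new, unique, unknown or untested is made for them only; others in the source may bear on it.

Measured so far in an assay on cells for inhibition of cytochrome P450 11B2, mitochondrial (Homo sapiens), read by HTRF; a higher number here means a weaker inhibitor, a lower number a stronger inhibitor:
compound 1 `CCC(=O)NCc1cncc(N2C(=O)c3ccc(Cl)cc3C2(C)C)c1`: 282 nM
compound 2 `CCC(=O)N[C@@H]1CCCc2c1cncc2N1C(=O)c2ccc(Cl)cc2[C@@H]1C`: 6 nM
compound 3 `CC(=O)NCc1cncc(N2C(=O)c3ccc(Cl)cc3C2(C)C)c1`: 59 nM

Compound 2 stands lowest of the three in this assay. How its core differs from that of compound 3 is not broken down here. Within the pair sharing a core, methyl in place of hydrogen on a saturated chain carbon bound to a carbonyl carbon gave a 4.8-fold higher number from compound 3 to compound 1 (0.68 log units; beyond the scatter).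

Compound 4 `CCC(=O)N[C@@H]1CCCc2c1cncc2N1C(=O)c2ccc(Cl)cc2[C@@H]1CC` is not yet measured. It is made from compound 2 by methyl in place of hydrogen on a saturated chain carbon bound to a saturated ring carbon. Among the compounds with values here, this is the same kind of change as the one from compound 3 to compound 1, but not the same: there the chain carbon is bound to a carbonyl carbon, here to a saturated ring carbon. Given that difference in surroundings, the earlier step is only a loose guide, so for compound 4 a step of a 2.0-fold higher number from compound 2 to compound 4 (0.30 log units; within the scatter) is expected, resting on the measured value of compound 2 of 6 nM and the direction seen from compound 3 to compound 1. The estimate for compound 4 in this assay is 12 nM.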

Compound 4, half-maximal inhibitory concentration: 12 nM
Estimate against measurement, compound 4: no gap at the digits printed; the measured number falls inside the stated range.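

In this assay, methyl in place of hydrogen on a saturated chain carbon bound to a saturated ring carbon gives a 2.0-fold higher number from compound 2 to compound 4 (0.30 log units; within the scatter). Set beside the earlier step, the change reads alike on the two cores within the scatter: the same change on two cores in this assay, a 4.8-fold higher number (0.68 log units; beyond the scatter) from compound 3 to compound 1 and a 2.0-fold higher number (0.30 log units; within the scatter) from compound 2 to compound 4, 2.4-fold (0.38 log units) apart, within the scatter of two such steps. This rests on two pairs only, with the chain carbon bound to a carbonyl carbon in one and to a saturated ring carbon in the other, and it does not show that the change would carry to further cores or places.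

Open, from the compounds shown here alone, is how a longer chain such as propyl, or a chain ending in an amine, would read in this assay at this place on the core of compound 2. Also open, going by these compounds, is whether a third core would give a step of similar size.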